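Swapping the Aryl Group on a Shared Core

The compounds below may be only part of what the source reports. "The series", "measured", "known", "first", "only" and "open" are said of these compounds alone.

Measured so far in a functional assay on HL-60 cells (Homo sapiens) for antiproliferative activity, read by MTT assay, with a stated time of 72 h; a lower number here means a stronger inhibitor, a higher number a weaker inhibitor:
Compound 1 `NC1=NC2(CCSCC2)N(OCCCOc2ccc(Cl)c(Cl)c2)C(N)=N1` gives 140 nM
Compound 2 `NC1=NC2(CCSCC2)N(OCCCOc2ccc(Br)cc2)C(N)=N1` gives 350 nM

Of these two compounds, compound 2 stands highest, and so is the weaker inhibitor in this assay. Going by the values given here, the only measured step between them is a 2.5-fold higher number from compound 1 to compound 2 (0.40 log units; beyond the scatter), a modest step that exceeds the scatter.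

The next compound is compound 3 `NC1=NC2(CCSCC2)N(OCCCOc2cccc(Cl)c2Cl)C(N)=N1`, which keeps the shared core and its chain. It differs from compound 2 by 2,3-dichlorophenyl in place of 4-bromophenyl on an oxygen on a saturated carbon, with 2,3-dichlorophenyl in place of 4-bromophenyl on an oxygen on a saturated carbon.

The measured step bears on this change only in part. Among the compounds with values here, it links 4-bromophenyl to 3,4-dichlorophenyl, a different dichlorophenyl, and no measurement yet shows how the two dichlorophenyl groups compare. A modest move toward a lower number is therefore expected, of about the size seen in the measured step. The expected change is a 1.8-fold lower number from compound 2 to compound 3 (0.24 log units; within the scatter) (an estimate only). For compound 3 the estimated value is 200 nM (expected range 80 nM to 500 nM).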

Compound 3, half-maximal inhibitory concentration: 30 nM
The estimate for compound 3 lay 6.7-fold (0.82 log units) above the measured number; measured number below the stated range.
By their numbers in this assay, from the lowest: compound 3; then compound 1; then compound 2.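

In this assay, going by these compounds alone, the aryl group on this oxygen proves able to move the number much further than the earlier pair suggested: the change to 2,3-dichlorophenyl gives a 12-fold lower number from compound 2 to compound 3 (1.07 log units; beyond the scatter), a large step, where the only earlier step was modest. The comparison of the two dichlorophenyl groups adds something the first two compounds could not show, since 2,3-dichlorophenyl in place of 3,4-dichlorophenyl gives a 4.7-fold lower number from compound 1 to compound 3 (0.67 log units; beyond the scatter), so at this position the arrangement of the chlorines on the ring matters, not only the presence of two of them. Nothing at hand explains this difference, and it stands as an observation only.

The compounds shown leave open whether the low number of compound 3 depends on both chlorines, since a plain phenyl, a chlorophenyl with a single chlorine or a methoxyphenyl would be needed to separate their parts. They also leave open whether the same order among the aryl groups would hold with a longer chain linking the aryl ether to the shared core.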